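Working notes: one methyl step repeated across two cores

The compounds below may be only part of what the source reports. "The series", "measured", "known", "first", "only" and "open" are said of these compounds alone.

Measured so far:
compound 1, `N/C(=N\NC(=S)N1CCCCCC1)c1ccccn1`: 36.6%
compound 2, `Cc1cccc(/C(N)=N/NC(=S)N2CCSCC2)n1`: 54.6%
compound 3, `N/C(=N\NC(=S)N1CCSCC1)c1ccccn1`: 39.7%

All three were run in a functional assay on HeLa cells (Homo sapiens) for cytotoxicity, read by MTT assay, with a stated time of 72 h, tested at 3 uM; a higher number here means more inhibition of growth at the concentration tested, a lower number less inhibition of growth. In this assay compound 3 gives 39.7% and compound 1 gives 36.6%; these two lie within the scatter of each other. The difference between the two cores is not broken down here. Compound 2 carries one change relative to compound 3, (methyl in place of hydrogen on an aromatic carbon), and that change gives a number 14.9 percentage points higher from compound 3 to compound 2 (beyond the scatter). The unmeasured compound 4, `Cc1cccc(/C(N)=N/NC(=S)N2CCCCCC2)n1`, stands to compound 1 as compound 2 stands to compound 3: methyl in place of hydrogen on an aromatic carbon. The place lines read the same word for word, so this is the same change on a different core. Compound 4 is expected to shift by a number 14.4 percentage points higher from compound 1 to compound 4 (beyond the scatter), because the same change gave a number 14.9 percentage points higher from compound 3 to compound 2 (beyond the scatter). Compound 4 is estimated at 51%, with a range from 40% to 62%.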

Compound 4, percent growth inhibition at one concentration: 63.6%
Compound 4: the middle estimate sits 12.6 percentage points below what was measured; measured number above the stated range.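

In this assay, methyl in place of hydrogen on an aromatic carbon gives a number 27 percentage points higher from compound 1 to compound 4 (beyond the scatter) and so points the same way on both cores. The two steps can be read as one effect of similar size: the same change on two cores in this assay, a number 14.9 percentage points higher (beyond the scatter) from compound 3 to compound 2 and a number 27 percentage points higher (beyond the scatter) from compound 1 to compound 4, 12.1 percentage points apart, within the scatter of two such steps. This does not show that the step would hold on a core beyond these two, and it gives no reason for the higher numbers.

The compounds shown leave open whether an ethyl, a methoxy or an amine on the same aromatic carbon would move the number as methyl does. They also leave open whether a ring on the thiocarbonyl nitrogen other than the two shown would keep the step.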